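Tetrazole regioisomers in an octylphenoxy ketone series

A few compounds are considered here, and "the series" means these few. Any claim that something is new, unique, unknown or untested is made for them only; others in the source may bear on it.

Measured compounds:
compound 1 `CCCCCCCCc1ccc(OCC(=O)Cn2nnc(C)n2)cc1`: 27 nM
compound 2 `CCCCCCCCc1ccc(OCC(=O)Cn2nnc(-c3ccccn3)n2)cc1`: 18 nM

In an assay on microsomes from brain for inhibition of Fatty-acid amide hydrolase 1 (Rattus norvegicus), read by fluorescence and HPLC, with a stated time of 60 min (a lower number here means a stronger inhibitor, a higher number a weaker inhibitor), compound 1 gives 27 nM and compound 2 gives 18 nM; the two numbers lie within the scatter of each other, so neither can be placed above the other. For the measured compounds named here, the only measured step, a 1.5-fold lower number from compound 1 to compound 2 (0.18 log units; within the scatter), swaps the substituent on the aromatic carbon of the tetrazole and leaves the number essentially where it was.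

Compound 3 `CCCCCCCCc1ccc(OCC(=O)Cn2nnnc2C)cc1` is not yet measured. It differs from compound 1 by 5-methyl-1H-tetrazol-1-yl in place of 5-methyl-2H-tetrazol-2-yl on a saturated chain carbon bound to a carbonyl carbon. Going by the values given here, this is a change in which ring nitrogen carries the methylene chain, not a change of substituent, and no measured step addresses it: the step from compound 1 to compound 2 touches only the group on the ring carbon and says nothing about the ring attachment point. The expectation for compound 3 therefore rests on compound 1 alone, with wide uncertainty in both directions and no basis to expect a large shift.

For compound 3 the estimate in this assay is 45 nM (range 12 nM to 160 nM), an expected step of a 1.7-fold higher number from compound 1 to compound 3 (0.22 log units; within the scatter).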

Compound 3, half-maximal inhibitory concentration: 41 nM
Beside the measured number, compound 3's estimate is 1.1-fold (0.04 log units) above it; low and high end bracket the measured number.
By their numbers in this assay, from the lowest: compounds 2, 1 and 3 (each within the scatter of the next, the first and the last beyond it).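

In this assay, placing 5-methyl-1H-tetrazol-1-yl in place of 5-methyl-2H-tetrazol-2-yl on a saturated chain carbon bound to a carbonyl carbon gives a 1.5-fold higher number from compound 1 to compound 3 (0.18 log units; within the scatter). For the compounds shown here, this is the first measured change at the point where the tetrazole joins the chain, and with the same atoms joined differently, the two methyl-bearing regioisomers cannot be told apart in this assay. The series therefore shows no dependence on which ring nitrogen carries the chain, a finding limited to this one pair with a methyl group on the ring carbon, and nothing available explains why the two isomers read alike.

Going by these compounds alone, it remains open whether the same holds when pyridin-2-yl, rather than methyl, sits on the ring carbon, since compound 2 has no counterpart here joined through the other ring nitrogen. Also open, from the compounds shown here alone, is how far the ring carbon accepts a group of a different kind, such as a carboxylic acid or an amine, and whether either regioisomer keeps its number with a shorter chain in place of the octyl chain.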